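This account rests on a few compounds, and the source may have more. Where it says the series, first, only, none or still open, it means among the compounds named here.

Compound 1, with the structure `COc1cc(/C=N/NC(=O)c2cc3ccccc3o2)ccc1O`, sits toward the upper end of the three numbers recorded so far. In a functional assay on K562 cells (Homo sapiens) for antiproliferative activity, read by cell counting, with a stated time of 7 days (on this read-out higher numbers stand for weaker inhibition and lower numbers for stronger inhibition), compound 1 gives 5600 nM. Compound 2, with the structure `O=C(N/N=C/c1ccc(O)c(O)c1O)c1cc2ccccc2o1`, gives 6000 nM in this assay, a value within the scatter of that of compound 1. Compound 3, with the structure `CCN(CC)c1ccc(/C=N/NC(=O)c2cc3ccccc3o2)c(O)c1`, gives 520 nM in this assay, a number well below both and beyond the scatter, so compound 3 is the only one of the three that stands apart.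

Compound 4, with the structure `O=C(N/N=C/c1ccc(O)cc1)c1cc2ccccc2o1`, has not yet been measured in this assay. It differs from compound 1 in one place: hydrogen in place of methoxy on an aromatic carbon. The shared core and the hydroxy group are kept; only the methoxy is gone.

Going by the values given here, no pair of measured compounds shows this exact change, so there is no measured step to lean on. Compound 2, with additional hydroxy groups, and compound 1, with a methoxy, sit within the scatter of each other, which suggests that substitution on that ring matters little unless a diethylamino group is present as in compound 3. Compound 4 is therefore expected to stay close to compound 1, with a step from compound 1 to compound 4 of about a 1.3-fold higher number from compound 1 to compound 4 (0.10 log units; within the scatter), which could fall in either direction within the scatter. The estimate for compound 4 in this assay is 7000 nM, within a range of 2500 nM to 20000 nM.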

Compound 4, half-maximal inhibitory concentration: 79900 nM
Compound 4: middle estimate off by 11-fold (1.06 log units), on the low side, outside the stated range (above it).
By their numbers in this assay, from the lowest: compound 3; then compounds 1 and 2 (each within the scatter of the next); then compound 4.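

In this assay, taking the methoxy away and leaving hydrogen on that aromatic carbon, ortho to a hydroxy group and meta to a large group, gives a 14-fold higher number from compound 1 to compound 4 (1.15 log units; beyond the scatter), a large loss of inhibition from the change of this one group. Going by these compounds alone, the earlier compounds offered no pair differing in one place, so this is the first direct reading of a single change on this ring, and it shows that this position is far from indifferent in the present series: with the shared core and the hydroxy group kept, the methoxy alone separates compound 1 from compound 4. The compounds shown offer no measurement that accounts for the size of this step, so it stands as an observation without an explanation.

The compounds shown leave open whether the methoxy is specifically needed or whether another group on the same carbon, such as ethoxy, chlorine or an amine, would hold the number of compound 1. They also leave open whether the step keeps its size when the hydroxy group is replaced, for instance by a fluorine atom, since this single pair tests the methoxy in only one setting.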